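Swapping the Aryl Group on the Saturated Ring Carbon

The compounds below may be only part of what the source reports. "The series", "measured", "known", "first", "only" and "open" are said of these compounds alone.

Three long-chain amides share one core and differ only in the group on a saturated ring carbon. In a functional assay on PC-3 cells (Homo sapiens) for antiproliferative activity, read by sulforhodamine B assay (a higher number here means a weaker inhibitor, a lower number a stronger inhibitor), compound 3 `CCCCCCCCCCCCCCCCCCNC(=O)[C@H]1CSC(c2c(Cl)cccc2Cl)N1` reports only a limit, > 20000 nM. Compound 1 `CCCCCCCCCCCCCCCCCCNC(=O)[C@H]1CSC(C2CCCCC2)N1` likewise reaches only a limit, > 20000 nM. Compound 2 `CCCCCCCCCCCCCCCCCCNC(=O)[C@H]1CSC(c2ccc(F)cc2)N1` gives a number, 6800 nM. Two of the three values thus sit at the limit of > 20000 nM in this assay, at which 2 of the 3 values shown sit, so compound 3 stands at the weak end of what this set shows. Compound 4 `CCCCCCCCCCCCCCCCCCNC(=O)[C@H]1CSC(c2ccc(C)cc2)N1` differs by 4-methylphenyl in place of 2,6-dichlorophenyl on a saturated ring carbon. For the measured compounds named here, the steps that bear on it are an at least 2.9-fold higher number from compound 2 to compound 3 (0.46 log units; beyond the scatter) and an at least 2.9-fold lower number from compound 1 to compound 2 (0.46 log units; beyond the scatter), both favouring 4-fluorophenyl. Compound 4 is therefore expected near 7000 nM, between 2500 nM and 20000 nM. That expectation means a step of an at least 2.8-fold lower number from compound 3 to compound 4 (0.45 log units; beyond the scatter).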

Compound 4, half-maximal inhibitory concentration: 12800 nM
Beside the measured number, compound 4's estimate is 1.8-fold (0.26 log units) below it; low and high end bracket the measured number.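

Compound 4 gives a second measured number at this position, so a readable value here does not depend on fluoro alone: 4-methylphenyl and 4-fluorophenyl cannot be told apart, with a 1.9-fold higher number from compound 2 to compound 4 (0.27 log units; within the scatter). Against the other two groups, the data give an at least 1.5-fold lower number from compound 3 to compound 4 (0.19 log units; that floor lies within the scatter) and an at least 1.5-fold lower number from compound 1 to compound 4 (0.19 log units; that floor lies within the scatter), so neither separation is secure. Both are only floors because compound 1 and compound 3 report limits: the limit of > 20000 nM in this assay, at which 2 of the 4 values shown sit.

The compounds shown leave open how an amine or a carboxylic acid on the aromatic ring would behave. They also leave open whether a shorter chain on the amide would change these values.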